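Benzyl for 4-chlorophenyl on compound 2: working notes

The source may hold more compounds than are shown below. What is called first, only, known or untested is meant among the compounds shown, and "the series" means these compounds.

Measured so far:
compound 1 `C/N=C(/NC#N)NCCCn1nc(-c2ccccc2)ccc1=O`: 40.5%
compound 2 `O=c1ccc(-c2ccccc2)nn1CCCCNC(=S)Nc1ccc(Cl)cc1`: 43.2%
compound 3 `N#CNC(=N)NCCCCCn1nc(-c2ccccc2)ccc1=O`: 31%

In a functional assay on the whole organism with Rattus norvegicus as the target, at a dose of 100 mg/kg (on this read-out higher numbers stand for more inhibition at the one dose given (going by the name of the read-out) and lower numbers for less inhibition), compound 2 gives the highest number of the three; compound 1 lies within the scatter of it, compound 3 beyond. Compound 4 `O=c1ccc(-c2ccccc2)nn1CCCCNC(=S)NCc1ccccc1` differs from compound 2 by benzyl in place of 4-chlorophenyl on an amide-type nitrogen. Within the data shown here, the only measured step, a number 9.5 percentage points lower from compound 1 to compound 3 (within the scatter), concerns a chain on the other side of the series and says nothing about the group on the amide-type nitrogen; no measured step bears on this change. With no guide, the expected step from compound 2 to compound 4 is a number 3.2 percentage points lower from compound 2 to compound 4 (within the scatter), none beyond the scatter. Compound 4 is therefore estimated at 40%, within 25% to 55%.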

Compound 4, a percentage reported as inhibition, in the whole organism at one dose (the size of the read-out at that dose, not a potency): 5.4%
Beside the measured number, compound 4's estimate is 34.6 percentage points above it; the whole stated range lies above it.
By their numbers in this assay, from the lowest: compound 4; then compounds 3, 1 and 2 (each within the scatter of the next, the first and the last beyond it).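

In this assay the group on the amide-type nitrogen matters strongly: benzyl in place of 4-chlorophenyl gives a number 37.8 percentage points lower from compound 2 to compound 4 (beyond the scatter). The two groups match in heavy-atom count, each has one six-membered aromatic ring of carbon only, and neither has hydrogen-bond donors or acceptors, so these counts do not separate the two compounds. Nothing available accounts for the loss.

The change removes the chlorine and adds a chain carbon in one step, so the two remain unseparated. Phenyl or 4-chlorobenzyl on this nitrogen would separate them.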